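A few compounds are considered here, and "the series" means these few. Any claim that something is new, unique, unknown or untested is made for them only; others in the source may bear on it.

Compound 2, `CCOC(=O)[C@@H]1CCCN(S(=O)(=O)c2ccc(S(=O)(=O)N3CCOCC3)cc2)C1`, has the highest number of the three compounds measured in a functional assay on MIA PaCa-2 cells (Homo sapiens) for inhibition, read by MTT assay, with a stated time of 7 days (a higher number here means a weaker inhibitor, a lower number a stronger inhibitor), giving 23500 nM. Within the data shown here, compound 1, `CCN(CC)S(=O)(=O)c1ccc(S(=O)(=O)N2CCC[C@@H](C(=O)N[C@@H]3CCN(C(=O)OC(C)(C)C)C3)C2)cc1`, gives 200 nM in this assay, and compound 3, `CCN(CC)S(=O)(=O)c1ccc(S(=O)(=O)N2CCC[C@@H](C(=O)N3CC4(CCN(C(=O)OC(C)(C)C)C4)C3)C2)cc1`, gives 190 nM; both differ from compound 2 in more than one place, so no single step separates them from it. Compound 4, `CCCN(CC)S(=O)(=O)c1ccc(S(=O)(=O)N2CCC[C@@H](C(=O)OCC)C2)cc1`, keeps the ethyl ester of compound 2 and changes only the amine on the sulfonyl: ethyl(propyl)amino in place of morpholin-4-yl on a sulfonyl sulfur. The two stronger compounds carry an open-chain amine there, but they also carry an amide, and the data do not separate the two changes. Compound 4 is expected to be somewhat stronger than compound 2, an estimated step of a 2.9-fold lower number from compound 2 to compound 4 (0.47 log units; beyond the scatter), with uncertainty. The value of compound 4 is estimated at 8000 nM, between 2000 nM and 25000 nM.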

Compound 4, half-maximal inhibitory concentration: 300 nM
Compound 4: the middle estimate sits 27-fold (1.43 log units) above what was measured; the measured number lies below the stated range.
By their numbers in this assay, from the lowest: compounds 3, 1 and 4 (each within the scatter of the next); then compound 2.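

In this assay, with the ethyl ester kept, ethyl(propyl)amino in place of morpholin-4-yl on a sulfonyl sulfur gives a 78-fold lower number from compound 2 to compound 4 (1.89 log units; beyond the scatter) and this large step comes from that one change. Among these compounds, the group on this sulfonyl therefore matters by itself, which the earlier compounds, differing in more than one place, could not show. Nothing available here gives a reason for the step. Still open, from the compounds shown here alone, is whether piperidin-1-yl or dimethylamino on this sulfonyl would give a similar step. Also open, going by these compounds, is whether the step would hold with a carboxylic acid in place of the ethyl ester.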